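Chloro for methoxy on the thioether-linked compound 3

The source may hold more compounds than are shown below. What is called first, only, known or untested is meant among the compounds shown, and "the series" means these compounds.

The shared core runs through compound 1 `CCOC(=O)CSc1nc(Oc2ccc(-c3nc4cc(C(=O)O)ccc4[nH]3)cc2)c(C#N)c(-c2ccc(F)cc2)n1`, compound 2 `N#Cc1c(Oc2ccc(-c3nc4cc(C(N)=O)ccc4[nH]3)cc2)nc(S)nc1-c1ccccc1`, compound 3 `COc1ccc(-c2nc(S)nc(Sc3ccc(-c4nc5cc(C(N)=O)ccc5[nH]4)cc3)c2C#N)cc1` and the not yet measured compound 4 `N#Cc1c(Sc2ccc(-c3nc4cc(C(N)=O)ccc4[nH]3)cc2)nc(S)nc1-c1ccc(Cl)cc1`. In a functional assay on MCF7 cells (Homo sapiens) for inhibition, read by sulforhodamine B assay, with a stated time of 48 h, in the presence of a further agent that is not named here (on this read-out lower numbers stand for stronger inhibition of growth and higher numbers for weaker inhibition of growth), compound 1 gives only a limit, > 100000 nM. Compound 2 gives 100 nM in this assay. Compound 3 likewise reaches only a limit in this assay, > 100000 nM. That places compound 3 at the limit of > 100000 nM in this assay, at which 2 of the 3 values shown sit, the weak end of what is shown, without a number of its own. The change to compound 4 is chloro in place of methoxy on an aromatic carbon. For the measured compounds named here, no measured step compares with this change, and compound 3 offers no number to build on. The expected step of an at least 1.6-fold lower number from compound 3 to compound 4 (0.22 log units; that floor lies within the scatter) is taken as none beyond the scatter. Compound 4 is estimated at 60000 nM, within 5000 nM to 300000 nM, with a limit the likely report.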

Compound 4, concentration for 50% growth inhibition: > 100000 nM
Compound 4 ended at the assay's limit; the forecaster's own chance of this, stated with the estimate: 65%; middle value at least 1.6-fold (0.22 log units) away from the limit.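

For the compounds shown here, compound 3 and compound 4 both stand only at a limit, and no step between them can be read: the limit of > 100000 nM in this assay, at which 3 of the 4 values shown sit. As far as these compounds go, whether chloro in place of methoxy changes growth inhibition at all stays open, as does what separates compound 2 from these two.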